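The source may hold more compounds than are shown below. What is called first, only, known or untested is meant among the compounds shown, and "the series" means these compounds.

Measured compounds:
Compound 1 `CN(C)c1ccc(-c2nc3c(s2)C(O)CNC3)cc1` gives 1600 nM in a functional assay on MCF7 cells (Homo sapiens) for cytotoxicity, read by sulforhodamine B assay, with a stated time of 2 days; a higher number here means a weaker inhibitor, a lower number a stronger inhibitor.
Compound 2 `OC1CNCc2nc(-c3ccc(N4CCCC4)cc3)sc21` gives 1530 nM in this assay.
Compound 3 `Cc1cc(N(C)C)ccc1-c1nc2c(s1)[C@H](O)CCC2` gives 730 nM in this assay.

Compound 2 stands second highest of these three numbers. The nearest number is that of compound 1. That step, a 1.0-fold lower number from compound 1 to compound 2 (0.02 log units; within the scatter), lies within the scatter, so the two are not distinguished. Among the measured compounds shown here, compound 3 shows a lower number, but no single-point step connects it to compound 2. Compound 4 `OCc1cc(N2CCCC2)ccc1-c1nc2c(s1)C(O)CNC2` differs from compound 2 by hydroxymethyl in place of hydrogen on an aromatic carbon. For the measured compounds named here, no measured step involves a hydroxymethyl group; the only step on this shared core, a 1.0-fold lower number from compound 1 to compound 2 (0.02 log units; within the scatter), left this assay unchanged within the scatter, so there is no basis for a shift in either direction. Compound 4 is therefore expected to give 1500 nM, with a range of 600 nM to 4000 nM. The expected step is a 1.0-fold lower number from compound 2 to compound 4 (0.01 log units; within the scatter), none beyond the scatter.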

Compound 4, half-maximal inhibitory concentration: 13 nM
The estimate for compound 4 lay 120-fold (2.06 log units) above the measured number; measured number below the stated range.
By their numbers in this assay, from the lowest: compound 4; then compound 3; then compounds 2 and 1 (each within the scatter of the next).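

In this assay, hydroxymethyl in place of hydrogen on this aromatic carbon gives a 120-fold lower number from compound 2 to compound 4 (2.07 log units; beyond the scatter). Among the compounds shown here, this position can therefore shift the number strongly, which the only earlier step on this core, a 1.0-fold lower number from compound 1 to compound 2 (0.02 log units; within the scatter), at a different place and within the scatter, could not show. No measurement at hand says what lies behind this step.

The compounds shown leave open how a methyl, a methoxy, an aminomethyl or a longer hydroxyethyl chain would fare on this carbon. They also leave open whether the same change would act alike with dimethylamino in place of pyrrolidin-1-yl.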